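Exchanging the aryl group on the oxygen of compound 3

The source may report more compounds than this note shows. Statements on the series, on what has been measured and on what is new or still open speak of the compounds shown alone.

Measured so far in a functional assay on MX1 cells (Homo sapiens) for antiproliferative activity, with a stated time of 72 h; on this read-out higher numbers stand for an effect only at larger amounts of compound and lower numbers for an effect already at smaller amounts:
Compound 1 `CCS(=O)(=O)Nc1ccc(Oc2ccccc2)c(-c2cn(C)c(=O)c3[nH]ccc23)c1`: 14 nM
Compound 2 `Cn1cc(-c2cc(S(N)(=O)=O)ccc2Oc2ccccc2)c2cc[nH]c2c1=O`: 56 nM
Compound 3 `Cn1cc(-c2cc(NS(C)(=O)=O)ccc2Oc2ccccc2C(F)(F)F)c2cc[nH]c2c1=O`: 83 nM

In this assay compound 3 gives 83 nM, which lies within the scatter of compound 2 at 56 nM. Compound 1 gives 14 nM, and the numbers of compound 2 and compound 3 both stand clearly higher. Compound 4 `Cn1cc(-c2cc(NS(C)(=O)=O)ccc2Oc2ccc(F)cc2Cl)c2cc[nH]c2c1=O` differs from compound 3 in one place: 2-chloro-4-fluorophenyl in place of 2-(trifluoromethyl)phenyl on an oxygen on an aromatic ring. Here 2-chloro-4-fluorophenyl takes the place of 2-(trifluoromethyl)phenyl on an oxygen on an aromatic ring. Among the compounds with values here, no measured step covers this exchange. Within the data shown here, the only one available, a 4.0-fold higher number from compound 1 to compound 2 (0.60 log units; beyond the scatter), concerns sulfamoyl and (ethylsulfonyl)amino elsewhere on the molecule, so it indicates only that a single change in this set can be modest in size. Compound 1 at 14 nM shows that lower numbers occur among these compounds, although it differs from compound 3 in more than one place. A modest step towards a lower number is therefore expected, with the direction uncertain. The expected change is a 2.1-fold lower number from compound 3 to compound 4 (0.32 log units; beyond the scatter). Compound 4 is estimated at 40 nM, with an expected range from 13 nM to 120 nM.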

Compound 4, half-maximal effective concentration: 27 nM
Beside the measured number, compound 4's estimate is 1.5-fold (0.17 log units) above it; measured number inside the range.
By their numbers in this assay, from the lowest: compounds 1 and 4 (each within the scatter of the next); then compounds 2 and 3 (each within the scatter of the next).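

In this assay, the aryl group on the oxygen now has a single exchange that can be read on its own: 2-chloro-4-fluorophenyl in place of 2-(trifluoromethyl)phenyl gives a 3.1-fold lower number from compound 3 to compound 4 (0.49 log units; beyond the scatter), a modest step beyond the scatter. Within the data shown here, the only earlier step concerned sulfamoyl and (ethylsulfonyl)amino elsewhere on the molecule, so this is the first sign in the set that the group on this oxygen also moves the number. Nothing available accounts for the shift seen with this exchange.

The two groups differ in more than one substituent, so the compounds shown do not tell whether the shift goes with the chlorine, the fluorine or the loss of trifluoromethyl. They also leave open how this position would respond to a methoxy-substituted phenyl, a pyridine ring or a cyclohexyl group on the oxygen.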